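The source may hold more compounds than are shown below. What is called first, only, known or untested is meant among the compounds shown, and "the series" means these compounds.

Of the compounds shown here, three sharing one core have been tested in a functional assay on aorta (strain Wistar) for inhibition, with Thoracic aorta (Rattus norvegicus) as the target; a lower number here means a stronger inhibitor, a higher number a weaker inhibitor. Compound 1 `COc1nc(-c2cc3ccccc3o2)cc(-c2ccc(Cl)cc2)c1C#N` gives 286000 nM. Compound 2 `COc1nc(-c2cc3ccccc3o2)cc(-c2ccc(F)cc2)c1C#N` gives 321000 nM, and compound 3 `CCOc1nc(-c2cc3ccccc3o2)cc(-c2ccc(F)cc2)c1C#N` gives 396000 nM. Compound 2 thereby stands second highest of the three numbers, with compound 1 as its nearest neighbour and compound 3 as its furthest; both steps, a 1.1-fold higher number from compound 1 to compound 2 (0.05 log units; within the scatter) and a 1.2-fold higher number from compound 2 to compound 3 (0.09 log units; within the scatter), lie within the scatter. Compound 4 `COc1nc(-c2cc3ccccc3o2)cc(-c2cccs2)c1C#N` has not yet been measured. It differs from compound 2 in one place: thiophen-2-yl in place of 4-fluorophenyl on an aromatic carbon. Of the measured steps, one touched the 4-fluorophenyl group through a change of halogen and gave a 1.1-fold higher number from compound 1 to compound 2 (0.05 log units; within the scatter); the other concerned the methoxy group and gave a 1.2-fold higher number from compound 2 to compound 3 (0.09 log units; within the scatter). Neither is a direct precedent for replacing that ring by a thiophen-2-yl, so the expectation can rest only on the observation that no change so far has moved this assay beyond its scatter. Compound 4 is therefore expected to show a step of a 1.1-fold lower number from compound 2 to compound 4 (0.03 log units; within the scatter), which amounts to no movement beyond the scatter. Compound 4 is estimated at 300000 nM, within a range from 150000 nM to 600000 nM.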

Compound 4, half-maximal inhibitory concentration: 163000 nM
Compound 4: the middle estimate sits 1.8-fold (0.26 log units) above what was measured, within the range that was stated.
By their numbers in this assay, from the lowest: compounds 4, 1, 2 and 3 (each within the scatter of the next, the first and the last beyond it).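

The thiophen-2-yl result extends what was known about this position, on an aromatic carbon opposite the ring nitrogen and ortho to a cyano group, from an exchange of one halogen for another to an exchange of the whole ring. In this assay, a six-membered aromatic ring of carbon only gives way to a five-membered aromatic ring with a hetero atom, yet both comparisons, a 2.0-fold lower number from compound 2 to compound 4 (0.29 log units; within the scatter) and a 1.8-fold lower number from compound 1 to compound 4 (0.24 log units; within the scatter), stay within the scatter, so the position accepts either ring type without a change that can be told apart from repeat measurement. Nothing available explains this tolerance or shows whether the sulfur atom or the smaller ring plays any part in it.

The compounds shown leave open whether anything other than an aromatic ring at this position, such as an amine, a carboxylic acid or a longer alkyl chain, would move the number in this assay beyond the scatter. They also leave open whether the thiophen-2-yl group would behave the same way with an ethoxy group in place of the methoxy group on the shared core.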